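A few compounds are considered here, and "the series" means these few. Any claim that something is new, unique, unknown or untested is made for them only; others in the source may bear on it.

Two compounds in the series share one core and differ only outside it. Compound 1 `CCOC(=O)[C@@H]1CC(=O)c2sccc2[C@H]1c1ccc(OC)cc1` and compound 2 `CCOC(=O)[C@@H]1CC(=O)c2sccc2[C@H]1c1ccccc1OC` have both been run in a physicochemical assay, read by spectrophotometry, with a stated time of 20 min, tested at 40 ug/mL; on this read-out higher numbers stand for a stronger effect at the one concentration tested and lower numbers for a weaker effect. In this assay compound 1 gives 16.7%. In this assay compound 2 gives 13.5%, a reading that lies within the scatter of compound 1, so neither compound can be set above the other on these two numbers. Compound 3 `CCOC(=O)[C@@H]1CC(=O)c2sccc2[C@H]1c1ccc(OC)cc1OC` remains to be measured. Relative to compound 2 the change is methoxy in place of hydrogen on an aromatic carbon. For the measured compounds named here, no step between two measured compounds is available to calibrate this change; the only guide is that compound 1 and compound 2 read alike. The expected step is a number 3.5 percentage points higher from compound 2 to compound 3 (within the scatter), a change not expected to pass beyond the scatter in either direction. Compound 3 is estimated at 17%, with a range from 7% to 30%.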

Compound 3, a percentage reported as activity, at one concentration (the size of the read-out at that concentration, not a potency): 11.8%
Compound 3: the middle estimate sits 5.2 percentage points above what was measured; the range from low to high includes it.
By their numbers in this assay, from the lowest: compounds 3, 2 and 1 (each within the scatter of the next).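

In this assay, methoxy in place of hydrogen on an aromatic carbon now has measured steps: a number 1.7 percentage points lower from compound 2 to compound 3 (within the scatter) and a number 4.9 percentage points lower from compound 1 to compound 3 (within the scatter). Both steps lie within the scatter, so adding a methoxy para to a large group, on a ring that already carries one methoxy, gives no reading that can be told apart from either compound with a single methoxy. No measured information bears on what lies behind these readings.

On these data alone, with methoxy as the only substituent on this ring across the three compounds, the reading of the unsubstituted ring remains open. Also open, as far as these compounds go, is whether an amine or a carboxylic acid at this position, para to the large group, would move the reading beyond the scatter.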